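A few compounds are considered here, and "the series" means these few. Any claim that something is new, unique, unknown or untested is made for them only; others in the source may bear on it.

Series notes on cytotoxicity. Compound 1 `C=C[C@@](C)(/C=C/c1ccc(OC)cc1)CCC=C(C)C` is tested in an ADME assay on BJ cells (Homo sapiens) for cytotoxicity, with a stated time of 72 h; a lower number here means that less compound is needed, a higher number that more compound is needed for the effect. In this assay compound 1 returns only a limit and no number, > 36600 nM. Compound 2 `C=C[C@@](C)(/C=C/c1ccc(O)cc1)CC/C=C/C(=O)OCC` likewise returns only a limit in this assay, > 36600 nM. Among the measured compounds shown here, both measured values thus sit at the limit of > 36600 nM in this assay, at which 2 of the 2 values shown sit, so compound 1 stands at the limit together with the only other measured compound, and no step between measured compounds can be read from the two of them.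

The next compound, compound 3 `C=C[C@@](C)(/C=C/c1ccc(-c2cccc(F)c2)cc1)CCC=C(C)C`, differs from compound 1 in one place: 3-fluorophenyl in place of methoxy on an aromatic carbon. For the measured compounds named here, with no measured step to lean on, no shift beyond the usual scatter of this assay is expected from this change. The expected step is a number no higher from compound 1 to compound 3 (the limit leaves the size open). Compound 3 is expected at 36600 nM, within 12000 nM to 100000 nM in this assay. A fair chance remains that the assay again reports only a limit for compound 3 rather than a number.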

Compound 3, half-maximal effective concentration: > 36600 nM
Compound 3: a limit, no number; the forecaster's own chance of this, stated with the estimate: 55%; the middle value lies on the limit itself.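

In this assay compound 3 returns only a limit, > 36600 nM. Compound 1 is also a limit, so no step from compound 1 to compound 3 can be read, and all values shown stand at one limit: the limit of > 36600 nM in this assay, at which 3 of the 3 values shown sit.

The compounds shown leave open whether 3-fluorophenyl in place of methoxy on an aromatic carbon changes the read-out at all.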